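This account rests on a few compounds, and the source may have more. Where it says the series, first, only, none or still open, it means among the compounds named here.

Compound 1 `CC(=O)N[C@@H]1CCCc2c1cncc2N1C(=O)c2ccc(Cl)cc2[C@@H]1C1CC1` — > 30000 nM
Compound 2 `CC1(C)CN(c2cccnc2)C(=O)c2ccc(Cl)cc21` — > 10000 nM
Compound 3 `O=C1c2ccccc2CN1c1cccnc1` — > 3000 nM

Of the compounds shown here, three have been measured in an ADME assay on cells for inhibition of cytochrome P450 11B1, mitochondrial (Homo sapiens), read by HTRF; on this read-out higher numbers stand for weaker inhibition and lower numbers for stronger inhibition. Each of them returned only a limit of the assay, not a number. Compound 1 sits at the limit of > 30000 nM in this assay, at which 1 of the 3 values shown sits. Compound 3 sits at the limit of > 3000 nM in this assay, at which 1 of the 3 values shown sits. Compound 2, the starting point of the step followed here, sits at the limit of > 10000 nM in this assay, at which 1 of the 3 values shown sits. On the numbers shown, compound 2 therefore cannot be ranked against the other two, as all three values are limits and no step between measured compounds can be drawn.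

The unmeasured compound 4 `CC1CN(c2cccnc2)C(=O)c2ccc(Cl)cc21` differs from compound 2 in one place: hydrogen in place of methyl on a saturated ring carbon. Going by the values given here, no measured pair shows this change, so its effect in this assay is unknown from the data at hand. Compound 2 gives only > 10000 nM in this assay, a limit. With the loss of a single methyl, compound 4 is expected to stay near that limit, with no step beyond the scatter in either direction. The step from compound 2 to compound 4 is estimated as a step that the limit leaves unreadable from compound 2 to compound 4. Compound 4 is expected to give about 20000 nM in this assay, within a range of 5000 nM to 60000 nM, and most likely to be reported only as a limit.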

Compound 4, half-maximal inhibitory concentration: 2590 nM
For compound 4 the middle estimate is 7.7-fold (0.89 log units) above the measured one; measured number below the stated range.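

In this assay, hydrogen in place of methyl on a saturated ring carbon gives an at least 3.8-fold lower number from compound 2 to compound 4 (0.58 log units; beyond the scatter), and since a lower number stands for stronger inhibition, this carbon, two ring bonds from the ring nitrogen, is a place where the loss of one methyl is felt on this read-out. Compound 4 is also the only compound shown that returns a number rather than a limit, and this is the only change in a single place that can be read. The full size of the step stays unknown because compound 2 carries only a limit: the limit of > 10000 nM in this assay, at which 1 of the 4 values shown sits.

Going by these compounds, compound 4 still carries one methyl on that carbon, so it remains open whether hydrogen in place of that methyl would lower the number further, and whether an ethyl group, a hydroxyl or an amine there would raise it or lower it. On these data alone, it is also open whether the same change would have a comparable effect on the core of compound 1 or in the presence of other groups on the pyridin-3-yl ring.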